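This account rests on a few compounds, and the source may have more. Where it says the series, first, only, none or still open, it means among the compounds named here.

Measured in a functional assay on A-431 cells (Homo sapiens) for inhibition, with a stated time of 72 h; a higher number here means a weaker inhibitor, a lower number a stronger inhibitor:
compound 1 `CC(C)OCc1cc(CN2CCCCC2)c(O)c2ncccc12`: 7410 nM
compound 2 `CCOCc1cc(CN2CCC(C)CC2)c(O)c2ncccc12`: 11000 nM
Not yet measured: compound 3 `CC1CCN(Cc2cc(COC(C)C)c3cccnc3c2O)CC1`

Compound 2, at 11000 nM, lies within the usual scatter of compound 1. Compound 3 differs from compound 2 in one place: methyl in place of hydrogen on a saturated chain carbon bound to an oxygen on a saturated carbon and a saturated chain carbon, on a saturated chain carbon bound to an oxygen on a saturated carbon and a saturated chain carbon, so ethoxymethyl becomes isopropoxymethyl. Among the compounds with values here, no measured pair shows this change alone, so no step beyond the scatter is expected in this assay, in either direction. The estimated change is a 1.2-fold lower number from compound 2 to compound 3 (0.09 log units; within the scatter). The estimate for compound 3 is 9000 nM, with an expected range of 4500 nM to 18000 nM.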

Compound 3, half-maximal inhibitory concentration: 7080 nM
Compound 3: the middle estimate sits 1.3-fold (0.10 log units) above what was measured, within the range that was stated.
By their numbers in this assay, from the lowest: compounds 3, 1 and 2 (each within the scatter of the next).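

In this assay, the change from ethoxymethyl to isopropoxymethyl gives a 1.6-fold lower number from compound 2 to compound 3 (0.19 log units; within the scatter), so adding this methyl on the saturated chain carbon bound to the oxygen does not move the number beyond the scatter. A methyl on a saturated ring carbon gives a 1.0-fold lower number from compound 1 to compound 3 (0.02 log units; within the scatter), which also stays within the scatter, so neither single change separates these compounds. No supporting measurement bears on these results.

Going by these compounds, whether a longer chain such as butoxymethyl, or a carboxylic acid in place of isopropoxymethyl, would give a step beyond the scatter remains open.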